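Extending the ribose series to the longer alkynyl chain

The compounds below may be only part of what the source reports. "The series", "measured", "known", "first", "only" and "open" are said of these compounds alone.

Among the measured compounds shown here, compound 3 `CCCCCCCCC#Cc1cc2cn([C@H]3C[C@H](O)[C@@H](CO)O3)c(=O)nc2o1` is the only member of the set with a measured number in a functional assay on HEL cells (Homo sapiens) for cytotoxicity; a higher number here means that more compound is tolerated, a lower number that less compound is tolerated: compound 3 gives 52000 nM. Compound 1 `CCCCC#Cc1cc2cn([C@@H]3O[C@H](CO)[C@@H](O)[C@H]3O)c(=O)nc2o1` reaches only a limit of the assay in this assay, > 144000 nM. Compound 2 `CCCCCCC#Cc1cc2cn([C@@H]3O[C@H](CO)[C@@H](O)[C@H]3O)c(=O)nc2o1` likewise stops at a limit, >= 133000 nM. For the measured compounds named here, the one step between measured neighbours, a step that the two limits leave unreadable from compound 1 to compound 2, is left unreadable by the two limits the limit of > 144000 nM in this assay, at which 1 of the 3 values shown sits, and (the limit of >= 133000 nM in this assay, at which 1 of the 3 values shown sits).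

Compound 4 `CCCCCCCCC#Cc1cc2cn([C@@H]3O[C@H](CO)[C@@H](O)[C@H]3O)c(=O)nc2o1` differs from compound 3 by hydroxy in place of hydrogen on a saturated ring carbon. Going by the values given here, no measured step covers this change; the nearest evidence is indirect: compound 1 and compound 2 carry the same 3,4-dihydroxy-5-(hydroxymethyl)oxolan-2-yl group as compound 4 and both sit at limits, whereas compound 3 shows a number. On that basis compound 4 is expected to be tolerated at a higher concentration than compound 3, an estimated step of a 1.9-fold higher number from compound 3 to compound 4 (0.28 log units; within the scatter), with a real chance of only a limit being reported. The estimate for compound 4 is 100000 nM, between 40000 nM and 250000 nM.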

Compound 4, minimum cytotoxic concentration: 49000 nM
For compound 4 the middle estimate is 2.0-fold (0.31 log units) above the measured one, within the range that was stated.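

In this assay, hydroxy in place of hydrogen on this saturated ring carbon leaves the number unmoved at the longer alkynyl chain, the step being a 1.1-fold lower number from compound 3 to compound 4 (0.03 log units; within the scatter). Among the compounds shown here, with the 3,4-dihydroxy-5-(hydroxymethyl)oxolan-2-yl group held fixed, chain length does register for the first time, as an at least 2.7-fold lower number from compound 2 to compound 4 (0.43 log units; beyond the scatter) and an at least 2.9-fold lower number from compound 1 to compound 4 (0.46 log units; beyond the scatter). Both steps start from a limit of the assay, so only their minimum size is known, and the step from compound 1 to compound 2 cannot be read.

Going by these compounds, it remains open whether the ring hydroxy is equally without consequence on the shorter chains. Also open, on these data alone, are how far a still longer chain would lower the number and what an amine in place of this hydroxy would do.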